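The source may hold more compounds than are shown below. What is called first, only, known or untested is meant among the compounds shown, and "the series" means these compounds.

Within the data shown here, in an ADME assay on the whole organism (Rattus norvegicus, strain Sprague-Dawley), read by LC-MS, with a stated time of 24 h, at a dose of 1 mg/kg by the intravenous route (on this read-out lower numbers stand for a shorter-lived compound and higher numbers for a longer-lived compound), compound 1 `CCN1C(=O)COc2c(CN3CCN(C(C)=O)CC3)cc(Nc3ncc(F)c(-c4ccc(F)cc4OC)n3)cc21` gives 0.309 h and compound 2 `CCN1C(=O)COc2c(CN3CCN(S(C)(=O)=O)CC3)cc(Nc3ncc(F)c(-c4ccc(F)cc4OC)n3)cc21` gives 0.247 h, so compound 2 stands within the scatter of the only other measured compound. Compound 3 `CCN(CC)Cc1cc(Nc2ncc(F)c(-c3ccc(F)cc3OC)n2)cc2c1OCC(=O)N2CC` carries diethylamino in place of 4-(methylsulfonyl)piperazin-1-yl on a saturated chain carbon bound to an aromatic carbon. Among the measured compounds shown here, the one measured step, a 1.3-fold lower number from compound 1 to compound 2 (0.10 log units; within the scatter), bears on this only loosely, since there methylsulfonyl replaced acetyl on an amine nitrogen in a ring, and the ring stayed. For the measured compounds named here, no measured compound shows what losing the ring does. Going by the small size of that step, a change in this assay no larger than the scatter is expected, perhaps toward a higher number. The expected move is a 1.6-fold higher number from compound 2 to compound 3 (0.21 log units; within the scatter). For compound 3 the estimate is 0.4 h, with an expected range of 0.17 h to 1 h.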

Compound 3, mean residence time: 0.689 h
The estimate for compound 3 lay 1.7-fold (0.24 log units) below the measured number; low and high end bracket the measured number.
By their numbers in this assay, from the lowest: compounds 2 and 1 (each within the scatter of the next); then compound 3.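

In this assay, the place on a saturated chain carbon bound to an aromatic carbon proves responsive: diethylamino in place of 4-(methylsulfonyl)piperazin-1-yl gives a 2.8-fold higher number from compound 2 to compound 3 (0.45 log units; beyond the scatter) and diethylamino in place of 4-acetylpiperazin-1-yl gives a 2.2-fold higher number from compound 1 to compound 3 (0.35 log units; beyond the scatter) as well. Both steps are modest, but unlike the exchange of acetyl for methylsulfonyl on the amine nitrogen in the ring, each lies beyond the scatter, so the open diethylamino group stands apart from both ring-bearing groups. No measurement shown explains this shift.

Going by these compounds, it remains open whether the change follows from opening the ring or from losing the acetyl or methylsulfonyl group with its nitrogen. A piperidine, a morpholine or an unsubstituted piperazine at this place would help to separate these two readings.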